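The compounds below may be only part of what the source reports. "The series", "measured", "known", "first", "only" and "open" are said of these compounds alone.

Three close relatives are compared here, all built on one shared core that carries an acetyl group and two phenyl rings. In compound 1 `CC(=O)c1cc(-c2ccc(F)cc2)cc2cc(-c3ccccc3)[nH]c12` one phenyl ring bears a fluoro group; compound 3 `CC(=O)c1cc(-c2ccccc2)cc2cc(-c3ccc(F)cc3)[nH]c12` has the same atoms joined differently, and the difference between the two cores is not broken down here. In a functional assay on HeLa cells (Homo sapiens) for cytotoxicity, read by MTT assay, with a stated time of 2 days, tested at 10 uM (a higher number here means a weaker effect of the compound at the concentration tested, a lower number a stronger effect), compound 1 gives 55.7%, while compound 3 gives 76.9%, the highest of the three numbers.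

Compound 2 `COc1ccc(-c2cc(C(C)=O)c3[nH]c(-c4ccccc4)cc3c2)cc1` differs from compound 1 by methoxy in place of fluoro on an aromatic carbon. In this assay compound 2 gives 33.9%, so that the change produced a number 21.8 percentage points lower from compound 1 to compound 2 (beyond the scatter).

Compound 4 `COc1ccc(-c2cc3cc(-c4ccccc4)cc(C(C)=O)c3[nH]2)cc1` has not yet been tested. It differs from compound 3 by methoxy in place of fluoro on an aromatic carbon, and the surroundings of the place are described in the same words as for the earlier pair, so this is the same change made a second time. Because the earlier pair showed a number 21.8 percentage points lower from compound 1 to compound 2 (beyond the scatter), a step of similar size is expected from compound 3 to compound 4, namely a number 21.9 percentage points lower from compound 3 to compound 4 (beyond the scatter). On that basis compound 4 is estimated to give 55%, with a likely range from 40% to 70%.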

Compound 4, a percentage reported as activity, at one concentration (the size of the read-out at that concentration, not a potency): 51.6%
The estimate for compound 4 lay 3.4 percentage points above the measured number; low and high end bracket the measured number.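

On the second core, methoxy in place of fluoro again lowered the number in this assay, giving a number 25.3 percentage points lower from compound 3 to compound 4 (beyond the scatter). Set side by side, the two steps agree: the same change on two cores in this assay, a number 21.8 percentage points lower (beyond the scatter) from compound 1 to compound 2 and a number 25.3 percentage points lower (beyond the scatter) from compound 3 to compound 4, 3.5 percentage points apart, within the scatter of two such steps. So the change from 4-fluorophenyl to 4-methoxyphenyl carried over from one core to the other with much the same size, but this rests on only two pairs, each read at a single concentration, so it does not show why the number falls, how potency changes, or whether the same step would appear on a third core.

The compounds shown leave open how other groups in the same place would read, such as a hydroxy group, an amine, a carboxylic acid or a longer chain like butoxy. They also leave open what the acetyl group contributes, as it stays the same in all four compounds.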